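A few compounds are considered here, and "the series" means these few. Any claim that something is new, unique, unknown or untested is made for them only; others in the source may bear on it.

Compound 1 `Cc1ccccc1NC(=O)N[C@@H](C)c1ccccc1` stands at the higher of the two numbers recorded so far: in an ADME assay on the whole organism with Oryza sativa as the target, tested at 10 uM (a lower number here means a stronger effect, a higher number a weaker effect of the compound at the concentration tested), compound 1 gives 99%. Compound 2 `Cc1ccc(NC(=O)N[C@H](C)c2ccccc2)cc1` gives 64% in this assay, a gap beyond the scatter. Compound 3 `CCc1ccccc1NC(=O)N[C@@H](C)c1ccccc1` has not been measured; it differs from compound 1 by methyl in place of hydrogen on a saturated chain carbon bound to an aromatic carbon. Going by the values given here, no step of this kind between measured compounds is available, so the size of the change is open. Compound 3 is expected to give 90% in this assay, between 70% and 100%. The step of a number 9 percentage points lower from compound 1 to compound 3 (within the scatter) that this estimate means is expected to be small, downward if anything, or none beyond the scatter.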

Compound 3, a percentage reported as activity, at one concentration (the size of the read-out at that concentration, not a potency): 95%
Estimate against measurement, compound 3: 5 percentage points below; measured number inside the range.
By their numbers in this assay, from the lowest: compound 2; then compounds 3 and 1 (each within the scatter of the next).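

In this assay, going by these compounds alone, the first step at this position, methyl in place of hydrogen on a saturated chain carbon bound to an aromatic carbon, comes out as a number 4 percentage points lower from compound 1 to compound 3 (within the scatter). The methyl to ethyl difference at this place therefore shows no effect beyond the scatter in the core of compound 1. No available evidence bears on this result. 

This single step leaves open whether a longer chain such as propyl, or an amine or a carboxylic acid at the same place, would move the number beyond the scatter.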